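This account rests on a few compounds, and the source may have more. Where it says the series, first, only, none or still open, it means among the compounds named here.

Three compounds have been measured in an assay on HEK-Blue hTLR2 cells for agonist activity at Toll-like receptor 2 (Homo sapiens), with a stated time of 24 h; on this read-out higher numbers stand for an effect only at larger amounts of compound and lower numbers for an effect already at smaller amounts:

compound 1 `CC(C)OC(=O)c1c(NC(=S)Nc2cccc3ccccc23)sc2c1CCC2`: 180 nM
compound 2 `CC(C)OC(=O)c1c(NC(=S)Nc2cccc3ccccc23)sc2c1CCCC2`: 140 nM
compound 3 `CC(C)COC(=O)c1c(NC(=S)Nc2cccc3ccccc23)sc2c1CCC2`: 28200 nM

Compound 1 and compound 2 give numbers that lie within the usual scatter of each other, so no order between them is claimed. Compound 3 stands apart: the change from compound 1 to compound 3 is isobutyl in place of isopropyl on an oxygen next to a carbonyl group, and it brings a 160-fold higher number from compound 1 to compound 3 (2.19 log units; beyond the scatter), a large step well beyond the scatter. The difference between the core of compound 1 and the core of compound 2 is not broken down here.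

Compound 4 `CC(C)COC(=O)c1c(NC(=S)Nc2cccc3ccccc23)sc2c1CCCC2` has not yet been measured in this assay. It arises from compound 2 by the same change, (isobutyl in place of isopropyl on an oxygen next to a carbonyl group), at the same place as in the pair of compound 1 and compound 3. Among the measured compounds shown here, only this one earlier instance of the change is available, and it sits on a different core, so the expectation rests on a single measured step. Compound 4 is expected to move by a 140-fold higher number from compound 2 to compound 4 (2.15 log units; beyond the scatter) because a 160-fold higher number from compound 1 to compound 3 (2.19 log units; beyond the scatter) comes from the same structural change, and because compound 2 gives 140 nM while compound 1 gives 180 nM, starting numbers that lie within the scatter of each other. Compound 4 is therefore estimated at 20000 nM in this assay, with a range from 4000 nM to 100000 nM that allows for the step being somewhat smaller or larger on the core of compound 2.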

Compound 4, half-maximal effective concentration: 30500 nM
For compound 4 the middle estimate is 1.5-fold (0.18 log units) below the measured one; low and high end bracket the measured number.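

In this assay, isobutyl in place of isopropyl on an oxygen next to a carbonyl group again gives a large step on the second core, a 220-fold higher number from compound 2 to compound 4 (2.34 log units; beyond the scatter). Set beside the earlier instance, the two steps cannot be told apart: the same change on two cores in this assay, a 160-fold higher number (2.19 log units; beyond the scatter) from compound 1 to compound 3 and a 220-fold higher number (2.34 log units; beyond the scatter) from compound 2 to compound 4, 1.4-fold (0.14 log units) apart, within the scatter of two such steps Within this series, the change therefore carried over from the core of compound 1 to the core of compound 2 with its size intact, but this rests on two pairs and two closely related cores only, so it does not show that the step would hold on any other core, nor does it explain why the change has so large an effect.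

The compounds shown leave open whether the large step belongs to isobutyl alone or would also appear with other groups on the same oxygen, such as ethyl, tert-butyl or a longer chain such as n-butyl. They also leave open what would happen if an amide took the place of the isopropoxycarbonyl group, and whether the step would keep its size if the group on the far side of the thiourea were different.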